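Halogen swap on the aryl ether: bromine to chlorine

The compounds below may be only part of what the source reports. "The series", "measured", "known", "first", "only" and "open" are said of these compounds alone.

Compound 2 `N#Cc1ccc(Nc2nc(Oc3c(Br)cc(Br)cc3Br)c3ccccc3n2)cc1` gives 58000 nM in an ADME assay on MT4 cells (Homo sapiens) for cytotoxicity, read by MTT assay, with a stated time of 4 days (on this read-out higher numbers stand for lower toxicity in this test and lower numbers for higher toxicity in this test), the lowest of the two numbers in hand; compound 1 `N#Cc1ccc(Nc2nc(Oc3ccc(Cl)cc3)c3ccccc3n2)cc1` gives 198000 nM in this assay. Compound 3 `N#Cc1ccc(Nc2nc(Oc3c(Cl)cc(Cl)cc3Cl)c3ccccc3n2)cc1` carries 2,4,6-trichlorophenyl in place of 2,4,6-tribromophenyl on an oxygen on an aromatic ring. Among the compounds with values here, the only measured step that touches this position is a 3.4-fold lower number from compound 1 to compound 2 (0.53 log units; beyond the scatter), which changed both the number and the pattern of halogens. For compound 3 a modest step upward is expected, a 1.5-fold higher number from compound 2 to compound 3 (0.17 log units; within the scatter), because a 3.4-fold lower number from compound 1 to compound 2 (0.53 log units; beyond the scatter) ran the other way and the chlorine set sits between the two measured ethers. Compound 3 is therefore estimated at 85000 nM, within 35000 nM to 220000 nM.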

Compound 3, half-maximal cytotoxic concentration: 56000 nM
Beside the measured number, compound 3's estimate is 1.5-fold (0.18 log units) above it; the measured number falls inside the stated range.
By their numbers in this assay, from the lowest: compounds 3 and 2 (each within the scatter of the next); then compound 1.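

In this assay, 2,4,6-trichlorophenyl in place of 2,4,6-tribromophenyl gives a 1.0-fold lower number from compound 2 to compound 3 (0.02 log units; within the scatter), so on this aryl ether the two halogens cannot be told apart. Set against 4-chlorophenyl, the same group gives a 3.5-fold lower number from compound 1 to compound 3 (0.55 log units; beyond the scatter), so the gap to compound 1 holds with either halogen. Nothing available bears on the origin of these numbers.

Going by these compounds, whether that gap follows the count of halogens or their pattern stays open: compound 1 differs from compound 2 and compound 3 in both. Also open, on these data alone, is how 2,4,6-trimethylphenyl, carrying no halogen, would read in this assay at this place.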